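The source may report more compounds than this note shows. Statements on the series, on what has been measured and on what is new or still open speak of the compounds shown alone.

Compound 1 `O=C1N/C(=N/c2ccc(Cl)cc2)S/C1=C\c1ccccn1` gives 41.7% in a functional assay on the whole organism (strain Swiss albino) for inhibition, with Mus musculus as the target, in the writhing test, with stated times of 30 min and 15 min, at a dose of 50 mg/kg by the oral route; on this read-out higher numbers stand for more inhibition at the one dose given (going by the name of the read-out) and lower numbers for less inhibition. Compound 2 `Cc1ccc(/N=C2/NC(=O)/C(=C/c3ccccn3)S2)cc1` carries methyl in place of chloro on an aromatic carbon and gives 43.2% in this assay; a number 1.5 percentage points higher from compound 1 to compound 2 (within the scatter). Compound 3 `O=C1N/C(=N/c2ccccc2Cl)S/C1=C\c1ccccn1` gives 36.2% in this assay; its core differs from the core of compound 1 by 2-chlorophenyl in place of 4-chlorophenyl on a double-bonded nitrogen, and a number 5.5 percentage points lower from compound 1 to compound 3 (within the scatter), while a number 7 percentage points lower from compound 2 to compound 3 (within the scatter). Compound 4 `Cc1ccccc1/N=C1/NC(=O)/C(=C/c2ccccn2)S1` is not yet measured; it differs from compound 3 by methyl in place of chloro on an aromatic carbon, the same kind of change as between compound 1 and compound 2, though here the place is ortho to a large group where before it was para to a large group. The step from compound 3 to compound 4 in this assay is expected to be a number 1.8 percentage points higher from compound 3 to compound 4 (within the scatter), because a number 1.5 percentage points higher from compound 1 to compound 2 (within the scatter) and the scatter of this read-out is broad. Compound 4 is thus expected to give 38% in this assay, likely between 28% and 48%.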

Compound 4, a percentage reported as inhibition, in the whole organism at one dose (the size of the read-out at that dose, not a potency): 43.6%
Beside the measured number, compound 4's estimate is 5.6 percentage points below it; the range from low to high includes it.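

In this assay, methyl in place of chloro on an aromatic carbon gives steps on the two cores that cannot be told apart: the same change on two cores in this assay, a number 1.5 percentage points higher (within the scatter) from compound 1 to compound 2 and a number 7.4 percentage points higher (within the scatter) from compound 3 to compound 4, 5.9 percentage points apart, within the scatter of two such steps. This shows no measurable dependence on the core, but it does not show that the change transfers, since a number 7.4 percentage points higher from compound 3 to compound 4 (within the scatter) is itself no distinct effect and neither is the earlier step. The two other new steps also stay inside the noise, a number 0.4 percentage points higher from compound 2 to compound 4 (within the scatter) and a number 1.9 percentage points higher from compound 1 to compound 4 (within the scatter), so 2-methylphenyl cannot be separated from 4-methylphenyl or 4-chlorophenyl on the double-bonded nitrogen.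

The compounds shown leave open how an amine, a carboxylic acid or a methoxy group would read on this phenyl ring. Also open, on these data alone, is whether any change there moves the number beyond the scatter.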